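The compounds below may be only part of what the source reports. "The series", "measured", "known", "first", "only" and "open" are said of these compounds alone.

Compound 1, with structure `CCc1cc(CCc2nc3c(C)cccc3o2)c(O)nc1C`, is measured in a functional assay on a cell-free system (plasma, Homo sapiens) for acid dissociation (a lower number here means tighter binding, a higher number weaker binding), and gives 2450 nM. Among the three compounds with numbers so far, compound 1 stands highest. Compound 2, with structure `CCc1cc(CCc2nc3c(C)ccc(C)c3o2)c(O)nc1C`, gives 1210 nM in this assay, and compound 3, with structure `CCc1cc(CCc2nc3c(Cl)ccc(Cl)c3o2)c(O)nc1C`, gives 760 nM. For the measured compounds named here, the only single-point step in the set is a 2.0-fold lower number from compound 1 to compound 2 (0.31 log units; beyond the scatter), which comes from a methyl in place of hydrogen on an aromatic carbon.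

Compound 4, with structure `CCc1cc(CCc2nc3c(F)cccc3o2)c(O)nc1C`, differs from compound 1 as follows: fluoro in place of methyl on an aromatic carbon. Going by the values given here, no measured pair exchanges methyl for fluoro, so the step from compound 1 to compound 2 bears on the change only loosely: it shows that a single methyl on the fused ring moves the number by a modest amount. Swapping that methyl for fluoro is therefore expected to shift the number little, if at all, and the step from compound 1 to compound 4 is estimated as a 1.1-fold higher number from compound 1 to compound 4 (0.03 log units; within the scatter). For compound 4 the expected value in this assay is 2600 nM, in the range 1200 nM to 5500 nM.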

Compound 4, dissociation constant: 24000 nM
Estimate against measurement, compound 4: 9.2-fold (0.97 log units) below; measured number above the stated range.
By their numbers in this assay, from the lowest: compounds 3 and 2 (each within the scatter of the next); then compound 1; then compound 4.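

In this assay, exchanging methyl for fluoro on this aromatic carbon gives a 9.8-fold higher number from compound 1 to compound 4 (0.99 log units; beyond the scatter). This is the largest single-place step seen so far, and it shows that the number depends strongly on which group sits at this position, more than a 2.0-fold lower number from compound 1 to compound 2 (0.31 log units; beyond the scatter), the step at another carbon of the same ring, could suggest. For the compounds shown here, nothing available explains why this one-atom exchange moves the number so far.

The compounds shown leave open whether the change comes from losing the methyl or from gaining the fluoro, a question that a plain hydrogen at this position would help to settle. Going by these compounds alone, they also leave open how a methoxy or a trifluoromethyl group, each placed here as the only change from compound 1, would compare with methyl and fluoro.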